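The source may report more compounds than this note shows. Statements on the series, on what has been measured and on what is new or still open speak of the compounds shown alone.

Measured so far in a functional assay on DU-145 cells (Homo sapiens) for cytotoxicity, read by MTT assay; on this read-out lower numbers stand for stronger inhibition and higher numbers for weaker inhibition:
compound 1 `CC(C)=CC[C@@H](OC[C@@H](C)O)C1=CC(=O)c2c(O)ccc(O)c2C1=O` gives 14300 nM
compound 2 `CCCC(C)(O)CC(=O)O[C@H](CC=C(C)C)C1=CC(=O)c2c(O)ccc(O)c2C1=O` gives 75000 nM

Compound 2 at 75000 nM holds the higher of the two numbers, which makes it the weaker inhibitor of the pair. Compound 3 `CC(C)=CC[C@@H](OC(=O)C1CCCOC1)C1=CC(=O)c2c(O)ccc(O)c2C1=O` keeps the shared core and the carbonyl, and the change is oxan-3-yl in place of 2-hydroxy-2-methylpentyl on a carbonyl carbon in that spot, with oxan-3-yl in place of 2-hydroxy-2-methylpentyl on a carbonyl carbon.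

Among the measured compounds shown here, one measured step bears on this, a 5.2-fold higher number from compound 1 to compound 2 (0.72 log units; beyond the scatter) as (2-hydroxy-2-methylpentyl)carbonyl took the place of 2-hydroxypropyl on an oxygen on a saturated carbon. That step is modest but beyond the scatter, and it involves the group that now leaves. For the measured compounds named here, no measured compound carries oxan-3-yl, so the guidance is thin. Going by the values given here, compound 2 tops a set of only two values and compound 1 at 14300 nM lies lower, so a modest move down is expected rather than a further rise. The expected change is a 2.1-fold lower number from compound 2 to compound 3 (0.33 log units; beyond the scatter) in size, though a step within the scatter would be no surprise. In this assay compound 3 is estimated at 35000 nM with 12000 nM to 90000 nM as the expected span.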

Compound 3, half-maximal inhibitory concentration: 29700 nM
Estimate against measurement, compound 3: 1.2-fold (0.07 log units) above, and the stated range covers the measured number.
By their numbers in this assay, from the lowest: compound 1; then compound 3; then compound 2.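

In this assay, the change on the carbonyl carbon alone gives a 2.5-fold lower number from compound 2 to compound 3 (0.40 log units; beyond the scatter), which shows that the group held by this carbonyl can move the number by itself, whereas the earlier step replaced the carbonyl and its chain together. The other comparison gives a 2.1-fold higher number from compound 1 to compound 3 (0.32 log units; beyond the scatter), so among these three compounds the two carrying a carbonyl at this oxygen both read higher than the 2-hydroxypropyl compound, and no compound shown goes against this. The number therefore depends on both the carbonyl-bearing link and the group it carries, although no supporting measurement here indicates what lies behind either step.

Going from 2-hydroxy-2-methylpentyl to oxan-3-yl closes a ring, removes a hydrogen-bond donor and changes the heavy-atom count all at once, so the compounds shown cannot separate these differences. As far as these compounds go, it also remains open how the number would respond on the same carbonyl carbon to a plain cyclohexyl ring, which has no ring oxygen, or to a piperidin-3-yl ring, which carries an amine.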